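The source may report more compounds than this note shows. Statements on the series, on what has been measured and on what is new or still open speak of the compounds shown alone.

In a functional assay on the whole organism (Tail, strain ICR) with Mus musculus as the target, in the tail flick test, with a stated time of 90 min, at a dose of 25 umol/kg by the oral route (on this read-out lower numbers stand for a weaker effect and higher numbers for a stronger effect at the one dose given), the three measured compounds stand as follows:

compound 1 `O=C(CN(c1nc(Cl)nc2[nH]cnc12)C1CC1)N[C@@H](CO)C(=O)OCc1ccccc1`: 34.5%
compound 2 `C[C@@H](O)[C@H](NC(=O)CN(c1nc(Cl)nc2[nH]cnc12)C1CC1)C(=O)OCc1ccccc1`: 29.9%
compound 3 `C[C@@H](O)[C@H](NC(=O)CN(c1ncnc2c1ncn2C1CCCCO1)C1CC1)C(=O)OCc1ccccc1`: 23.4%

Compound 1 and compound 2 share one core, while compound 3 is built on another; the difference between the two cores is not broken down here. Compound 2 and compound 1 differ in a single place, (hydrogen in place of methyl on a saturated chain carbon bound to an oxygen on a saturated carbon and a saturated chain carbon), and this change gave a number 4.6 percentage points higher from compound 2 to compound 1 (within the scatter). Compound 3 sits within the usual scatter of compound 2, whereas compound 1 lies beyond the scatter above compound 3.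

The unmeasured compound 4 `O=C(CN(c1ncnc2c1ncn2C1CCCCO1)C1CC1)N[C@@H](CO)C(=O)OCc1ccccc1` is compound 3 carrying the same change, (hydrogen in place of methyl on a saturated chain carbon bound to an oxygen on a saturated carbon and a saturated chain carbon), at the same place. Within the data shown here, the only guide to what it may do is the pair already measured. Compound 4 is expected to move by about a number 4.6 percentage points higher from compound 3 to compound 4 (within the scatter) from compound 3, a step of the same small size as the one seen, because the pair of compound 2 and compound 1 showed only a number 4.6 percentage points higher from compound 2 to compound 1 (within the scatter). On that basis compound 4 is estimated to give 28% in this assay. The estimate for compound 4 is expected to fall between 15% and 41%, the width reflecting that one earlier pair alone, on a different core, supports it.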

Compound 4, a percentage reported as activity, at one dose (the size of the read-out at that dose, not a potency): 32.2%
The estimate for compound 4 lay 4.2 percentage points below the measured number, and the stated range covers the measured number.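

In this assay, replacing 1-hydroxyethyl with hydroxymethyl on the core of compound 3 gave a number 8.8 percentage points higher from compound 3 to compound 4 (within the scatter). Set beside the same change on the core of compound 1, the two steps cannot be told apart, so the change looks the same on both cores as far as this test can show: the same change on two cores in this assay, a number 4.6 percentage points higher (within the scatter) from compound 2 to compound 1 and a number 8.8 percentage points higher (within the scatter) from compound 3 to compound 4, 4.2 percentage points apart, within the scatter of two such steps

This agreement suggests that, in these two pairs, the effect of the change does not depend noticeably on the core, but it does not prove that the change itself strengthens the effect, as each step taken alone stays within the usual scatter, and two pairs say nothing about any further core.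

The compounds shown leave open what a group other than hydroxyl-bearing 1-hydroxyethyl or hydroxymethyl would do at this place, such as an aminomethyl group or a longer chain like 2-hydroxypropyl, and also what a carboxylic acid would do in place of the benzyl ester. They also give only one dose at one stated time, so a larger step might still appear under other conditions, and whether the two cores would then stay alike remains an open question.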